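The compounds below may be only part of what the source reports. "The series", "measured", "known", "first", "only" and "open" are said of these compounds alone.

- compound 1 `Cc1ccsc1/C=C(/SCc1ccc(Cl)cc1)C(=O)c1ccc(Cl)cc1`: 50000 nM
- compound 2 `COc1ccccc1/C=C(/SCc1ccc(Cl)cc1)C(=O)c1ccc([N+](=O)[O-])cc1`: 10000 nM
- compound 3 `COc1ccccc1/C=C(/SCc1ccc(Cl)cc1)C(=O)c1ccc(Cl)cc1`: 1000 nM

In a functional assay on DU-145 cells (Homo sapiens) for inhibition, read by trypan blue exclusion, with a stated time of 96 h (a higher number here means a weaker inhibitor of growth, a lower number a stronger inhibitor of growth), compound 3 gives 1000 nM, the lowest of the three numbers and so the strongest inhibitor of growth measured here. The unmeasured compound 4 `COc1ccccc1/C=C(/SCc1ccccc1F)C(=O)c1ccc(Cl)cc1` changes compound 3 in one place: 2-fluorophenyl in place of 4-chlorophenyl on a saturated chain carbon bound to a sulfur. In words, 2-fluorophenyl stands in place of 4-chlorophenyl on a saturated chain carbon bound to a sulfur.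

Neither measured step touches this place, since all three measured compounds carry the 4-chlorobenzyl group. One step, a 50-fold lower number from compound 1 to compound 3 (1.70 log units; beyond the scatter), exchanges the group on the double-bonded chain carbon. The other, a 10-fold lower number from compound 2 to compound 3 (1.00 log units; beyond the scatter), puts chloro in place of nitro on an aromatic carbon. Both lie beyond the scatter, so single changes elsewhere in these compounds can shift the number considerably, but they give no direct guide to the direction of this new change. Going by the values given here, with compound 3 at 1000 nM, the lowest number so far, a small rise seems somewhat more likely than a further fall, though this is only a weak expectation.

The expected change is a 2.0-fold higher number from compound 3 to compound 4 (0.30 log units; within the scatter), and it remains highly uncertain. For compound 4 the estimate is 2000 nM, with an expected range of 500 nM to 8000 nM.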

Compound 4, concentration for 50% growth inhibition: 10000 nM
Compound 4: the middle estimate sits 5.0-fold (0.70 log units) below what was measured, outside the stated range (above it).
By their numbers in this assay, from the lowest: compound 3; then compounds 2 and 4 (each within the scatter of the next); then compound 1.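

In this assay, the group on the saturated chain carbon bound to a sulfur proves to matter: with 2-fluorophenyl in place of 4-chlorophenyl, the step is a 10-fold higher number from compound 3 to compound 4 (1.00 log units; beyond the scatter). All the earlier compounds carried 4-chlorophenyl here, so they could show only what happens elsewhere in the molecule, whereas this result shows that the number also responds to a change at this place and that, among these four compounds, compound 3 keeps the lowest number. However, 4-chlorophenyl and 2-fluorophenyl differ both in the halogen and in where it sits on the ring, so this single step cannot separate those two differences, and nothing measured here explains the rise.

The compounds shown leave open whether 2-chlorophenyl or 4-fluorophenyl at this place would fall nearer compound 3 or compound 4, which would help to tell the halogen from its location. They also leave open how a plain phenyl ring without a halogen, or a longer chain between the sulfur and the ring, would compare, and whether the same step would appear with the nitro group of compound 2 in place of the chloro.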